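Swapping a saturated amine for an anilino group

This account rests on a few compounds, and the source may have more. Where it says the series, first, only, none or still open, it means among the compounds named here.

Compound 1 `COC(CCn1cnc2c(NCc3ccc(C(=O)Nc4ccccc4N)cc3)nc(Cl)nc21)OC`: 34.2%
Compound 2 `Cc1ccc(Nc2nc(Cl)nc3c2ncn3Cc2ccc(C(=O)Nc3ccccc3N)cc2)cc1`: 82%
Compound 3 `CC1CCN(c2nc(Cl)nc3c2ncn3Cc2ccc(/C=C/C(=O)Nc3ccccc3N)cc2)CC1`: 32.2%

In a functional assay on HepG2 cells (Homo sapiens) for antiproliferative activity, read by CCK-8 assay, with a stated time of 72 h, tested at 8 uM (on this read-out lower numbers stand for a weaker effect and higher numbers for a stronger effect at the one concentration tested), compound 3 gives 32.2%, the lowest of the three numbers, though compound 1 lies within the scatter of it, while compound 2 stands well beyond it. Compound 4 `Cc1ccc(Nc2nc(Cl)nc3c2ncn3Cc2ccc(/C=C/C(=O)Nc3ccccc3N)cc2)cc1` differs from compound 3 in one place: (4-methylphenyl)amino in place of 4-methylpiperidin-1-yl on an aromatic carbon. Compound 2, which carries the same (4-methylphenyl)amino group on its core, gives 82%, and this is the basis for the expectation. The step of a number 35.8 percentage points higher from compound 3 to compound 4 (beyond the scatter) is expected to be upward and beyond the scatter. Compound 4 is expected to reach 68%, with a range from 45% to 88%.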

Compound 4, a percentage reported as inhibition, at one concentration (the size of the read-out at that concentration, not a potency): 43%
For compound 4 the middle estimate is 25 percentage points above the measured one; the whole stated range lies above it.
By their numbers in this assay, from the lowest: compounds 3, 1 and 4 (each within the scatter of the next, the first and the last beyond it); then compound 2.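

In this assay, (4-methylphenyl)amino in place of 4-methylpiperidin-1-yl gives only a modest gain, a number 10.8 percentage points higher from compound 3 to compound 4 (beyond the scatter). With that group held constant, 2-((2-aminophenyl)carbamoyl)ethenyl in place of (2-aminophenyl)carbamoyl gives the larger change, a number 39 percentage points lower from compound 2 to compound 4 (beyond the scatter), so the high value of compound 2 does not carry over with the (4-methylphenyl)amino group alone. Nothing available here accounts for either step. On these data alone, it remains open whether a morpholine ring or a methoxy-substituted anilino group at this position would read differently. As far as these compounds go, it is also open whether a longer chain in place of the ethenyl link would lower the number further.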